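Diaryl ether amines: chain extension from compound 2

This account rests on a few compounds, and the source may have more. Where it says the series, first, only, none or still open, it means among the compounds named here.

Two compounds carry the shared core of compound 1 `COc1ccc(CNCc2c(OC)cc(Oc3cccc(Nc4ccccc4)c3)cc2OC)cc1`, which in a functional assay on HCT-116 cells (Homo sapiens) for inhibition, read by MTT assay, with a stated time of 72 h (a lower number here means a stronger inhibitor, a higher number a weaker inhibitor), gives 2620 nM. Compound 2 `COc1cc(Oc2cccc(Nc3ccccc3)c2)cc(OC)c1CNCc1ccc(Cl)cc1` gives 3310 nM in this assay; it holds the highest of the two numbers, its nearest neighbour being compound 1, and the step of a 1.3-fold higher number from compound 1 to compound 2 (0.10 log units; within the scatter) stays within the scatter. Compound 3 `COc1ccc(CCCNCc2c(OC)cc(Oc3cccc(Nc4ccccc4)c3)cc2OC)cc1` is not yet measured. Its change from compound 2 is 2-(4-methoxyphenyl)ethyl in place of 4-chlorophenyl on a saturated chain carbon bound to an amine nitrogen. Going by the values given here, no measured step covers a lengthening of the chain on the amine nitrogen; the only step available, from compound 1 to compound 2, swapped a ring substituent and was within the scatter. The expectation for compound 3 in this assay is therefore a step of a 1.1-fold lower number from compound 2 to compound 3 (0.04 log units; within the scatter), not beyond the scatter. Compound 3 is estimated at 3000 nM, within a range from 1000 nM to 9000 nM.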

Compound 3, half-maximal inhibitory concentration: 2850 nM
Compound 3: middle estimate off by 1.1-fold (0.02 log units), on the high side; measured number inside the range.
By their numbers in this assay, from the lowest: compounds 1, 3 and 2 (each within the scatter of the next).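

On the saturated chain carbon bound to an amine nitrogen, 2-(4-methoxyphenyl)ethyl in place of 4-chlorophenyl gives a 1.2-fold lower number from compound 2 to compound 3 (0.06 log units; within the scatter) in this assay, and in place of 4-methoxyphenyl it gives a 1.1-fold higher number from compound 1 to compound 3 (0.04 log units; within the scatter). The earlier step covered only a ring substituent; these two show that the 3-(4-methoxyphenyl)propyl chain on the amine nitrogen, which replaces a benzyl group, also leaves the number within the scatter, so compound 1, compound 2 and compound 3 cannot be told apart here. No evidence on hand bears on this result.

On these data alone, all three compounds end in a substituted aromatic ring, so the reach of this tolerance remains open. Whether a longer chain, or a chain ending in a carboxylic acid or a morpholine, would move the number beyond the scatter cannot be told from these compounds.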